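Phenyl for Benzyl Against a Shared Cytotoxicity Limit

The source may hold more compounds than are shown below. What is called first, only, known or untested is meant among the compounds shown, and "the series" means these compounds.

Compound 1 `O=C(CCCCCCCc1ccccc1)N[C@H]1CCOC1=O` carries a benzyl group at the far end of a long saturated chain that is joined to an amide. In a functional assay on NCI-H630 cells (Homo sapiens) for cytotoxicity, read by sulforhodamine B assay, with a stated time of 5 days (a higher number here means a weaker inhibitor, a lower number a stronger inhibitor), compound 1 gives > 100000 nM, which is a limit of the assay rather than a number. Compound 2 `O=C(CCCc1ccccc1)CC(=O)N[C@H]1CCOC1=O` and compound 3 `O=C(CCc1ccccc1)CC(=O)N[C@H]1CCOC1=O` share a core whose difference from the core of compound 1 is not broken down here. In this assay compound 2 gives > 100000 nM, again a limit. In this assay compound 3 gives > 100000 nM, also a limit. Compound 3 arises from compound 2 through (phenyl in place of benzyl on a saturated chain carbon, two bonds along the chain from a carbonyl carbon); this gives a step that the two limits leave unreadable from compound 2 to compound 3. That nothing can be read from this pair rests on (the limit of > 100000 nM in this assay, at which 3 of the 3 values shown sit).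

Compound 4 `O=C(CCCCCCc1ccccc1)N[C@H]1CCOC1=O` is not yet measured. It arises from compound 1 through (phenyl in place of benzyl on a saturated chain carbon, six bonds along the chain from a carbonyl carbon). For the measured compounds named here, this is the same kind of change as the one from compound 2 to compound 3, but not the same change: there the place is two bonds along the chain from a carbonyl carbon, here it is six bonds along the chain from a carbonyl carbon. Since (the limit of > 100000 nM in this assay, at which 3 of the 3 values shown sit), compound 4 is expected to sit at that same limit, so the step from compound 1 to compound 4 is estimated as a step that the limit leaves unreadable from compound 1 to compound 4. In this assay compound 4 is expected to give about 150000 nM, most likely reported once more only as a limit, with an estimated range from 60000 nM to 500000 nM.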

Compound 4, half-maximal inhibitory concentration: > 100000 nM
Compound 4 gave a limit, no number (the forecaster's own chance of this, stated with the estimate: 90%); the middle value is on the limit's open side.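

Compound 4 gives > 100000 nM in this assay, which is a limit of the assay and not a number. No step can be read from compound 1 to compound 4, since both compounds sit at a limit: the limit of > 100000 nM in this assay, at which 4 of the 4 values shown sit.

The compounds shown leave open whether any change to these structures would bring a measurable value in this assay.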